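The source may report more compounds than this note shows. Statements on the series, on what has been measured and on what is new or still open speak of the compounds shown alone.

Series notes. Of the compounds shown here, three have numbers so far. Compound 1 `COc1ccc(NC(=O)C2CCc3ccccc3N2)cc1` gives 50200 nM in a functional assay on HCT-15 cells (Homo sapiens) for cytotoxicity, read by sulforhodamine B assay, with a stated time of 72 h; on this read-out higher numbers stand for weaker inhibition of growth and lower numbers for stronger inhibition of growth. Compound 2 `O=C(Nc1cc(C(F)(F)F)cc(C(F)(F)F)c1)C1CCc2ccccc2N1C(=O)c1ccc(Cl)cc1` gives 2220 nM in this assay, and compound 3 `O=C(Nc1ccccc1C(F)(F)F)C1CCc2ccccc2N1C(=O)c1ccccc1Cl` gives 4220 nM. Compound 2 holds the lowest of the three numbers; the gap to compound 1 lies beyond the usual scatter, while compound 3 sits close enough that no order between compound 2 and compound 3 can be read from these two values. Going by the values given here, no pair of the measured compounds differs in just one place, so no single-point step is available as a guide.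

The next compound, compound 4 `O=C(Nc1cc(C(F)(F)F)cc(C(F)(F)F)c1)C1CCc2ccccc2N1C(=O)c1ccccc1`, is compound 2 with one change: hydrogen in place of chloro on an aromatic carbon. Read one bond further out, the 4-chlorophenyl becomes a phenyl and the (4-chlorophenyl)carbonyl a benzoyl. Among the compounds with values here, nothing among the measured compounds isolates this change, so the expectation rests on the general run of such exchanges. The step from compound 2 is expected to be small, leaning toward a weaker number and most likely staying within the scatter; the estimated step is a 1.4-fold higher number from compound 2 to compound 4 (0.16 log units; within the scatter). For compound 4 the estimate in this assay is 3200 nM, with a range from 1300 nM to 8000 nM.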

Compound 4, concentration for 50% growth inhibition: 3540 nM
The estimate for compound 4 lay 1.1-fold (0.04 log units) below the measured number; the range from low to high includes it.
By their numbers in this assay, from the lowest: compounds 2, 4 and 3 (each within the scatter of the next); then compound 1.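

In this assay, going by these compounds alone, the exchange of chloro for hydrogen on this aromatic carbon gives a 1.6-fold higher number from compound 2 to compound 4 (0.20 log units; within the scatter) and is the first single-place step available. With the rest of compound 2 held fixed, the 4-chlorophenyl and the phenyl therefore cannot be told apart on this read-out, and the chloro is not required for a number in this range. Nothing in the available data offers an explanation for this result.

As far as these compounds go, only chloro and hydrogen have been compared at this position, so it remains open how an amine, a carboxylic acid or a longer chain such as an alkoxy chain would read there. From the compounds shown here alone, it is also open whether the same exchange would give a similar step with a different group on the amide nitrogen.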